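Demethylation of an Aryl Methoxy Group: A Cytotoxicity Estimate

This account rests on a few compounds, and the source may have more. Where it says the series, first, only, none or still open, it means among the compounds named here.

Compound 1 `Cc1cc(O)cc(-c2nn(CC#N)cc2-c2ccnc(-c3ccc(Oc4ccccc4)cc3)c2)c1` gives 39500 nM in a functional assay on HOP-92 cells (Homo sapiens) for inhibition, read by sulforhodamine B assay, with a stated time of 48 h; on this read-out lower numbers stand for higher toxicity in this test and higher numbers for lower toxicity in this test.
Compound 2 `COc1cc(C)cc(-c2nn(CC#N)cc2-c2ccnc(-c3ccc(N(C)C)cc3)c2)c1` gives > 100000 nM in this assay.

Compound 2 stands at the edge of what this assay reports: its value is a limit, not a number (the limit of > 100000 nM in this assay, at which 1 of the 2 values shown sits). Compound 1, which carries a hydroxy where compound 2 carries a methoxy and a different pendant group, does give a number within the range of this assay. Compound 3 `Cc1cc(O)cc(-c2nn(CC#N)cc2-c2ccnc(-c3ccc(N(C)C)cc3)c2)c1` is still to be measured. It differs from compound 2 in one place: hydrogen in place of methyl on an oxygen on an aromatic ring. Among the measured compounds shown here, no measured pair shows this change on its own, so its size and direction cannot be read from the data. The step of an at least 1.2-fold lower number from compound 2 to compound 3 (0.09 log units; that floor lies within the scatter) is expected to be modest, bringing compound 3 to about the limit or just inside it. Compound 3 is therefore estimated at 80000 nM, with a range from 30000 nM to 200000 nM, and a fair chance that only a limit is reported again.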

Compound 3, concentration lethal to 50% of the cells: > 100000 nM
Compound 3 was reported as a limit; the forecaster's own chance of this, stated with the estimate: 45%; middle value at least 1.2-fold (0.09 log units) from the limit.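

In this assay, compound 3 gives > 100000 nM, which is a limit of the assay and not a number. Dimethylamino in place of phenoxy on an aromatic carbon, with the hydroxy kept, now has a readable effect on this read-out: an at least 2.5-fold higher number from compound 1 to compound 3 (0.40 log units; beyond the scatter), toward lower toxicity in this test. The step for hydrogen in place of methyl on the oxygen cannot be read, and the set now gathers at the edge of what the assay reports: the limit of > 100000 nM in this assay, at which 2 of the 3 values shown sit.

The compounds shown leave open whether methoxy to hydroxy has any size at all when the pendant group is phenoxy, where a number can be read. They also leave open how a morpholine in place of dimethylamino, or a carboxylic acid in place of hydroxy, would stand in this assay.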